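Pyridinyl Alkyne Analogue in an mGlu5 Modulator Series

The source may report more compounds than this note shows. Statements on the series, on what has been measured and on what is new or still open speak of the compounds shown alone.

Compound 2, `C[C@@H](NC(=O)c1ccc(C#Cc2ccccc2F)cn1)C(C)(C)O`, gives 60% in a functional assay on HEK293 cells for positive allosteric modulation of metabotropic glutamate receptor 5 (Rattus norvegicus), read by fluorescence and calcium flux; on this read-out higher numbers stand for larger maximal responses and lower numbers for smaller maximal responses. Its number is the lowest of the three measured, but compound 1, `C[C@@H](NC(=O)c1ccc(C#Cc2ccccc2)cn1)C(C)(C)O`, at 60.9%, and compound 3, `C[C@@H](NC(=O)c1ccc(C#Cc2ccc(F)cc2F)cn1)C(C)(C)O`, at 61.2%, both sit within the scatter of it. Compound 4, `C[C@@H](NC(=O)c1ccc(C#Cc2ccncc2)cn1)C(C)(C)O`, differs from compound 2 by pyridin-4-yl in place of 2-fluorophenyl on a triple-bonded carbon. Among the measured compounds shown here, the steps that bear on this exchange, all on the ring attached to the triple-bonded carbon, are a number 0.9 percentage points lower from compound 1 to compound 2 (within the scatter), a number 0.3 percentage points higher from compound 1 to compound 3 (within the scatter) and a number 1.2 percentage points higher from compound 2 to compound 3 (within the scatter), each within the scatter. For the measured compounds named here, those steps only traded hydrogen for fluorine, whereas compound 4 introduces a ring nitrogen, for which no measured precedent exists here. Compound 4 is expected to show no change at the digits printed from compound 2 to compound 4 (within the scatter), no change beyond the scatter. Compound 4 is therefore estimated at 60%, between 48% and 70%.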

Compound 4, largest response reached (reported as efficacy), in percent of the reference or control that the assay uses: 66.6%
Estimate against measurement, compound 4: 6.6 percentage points below; the measured number falls inside the stated range.
By their numbers in this assay, from the lowest: compounds 2, 1, 3 and 4 (each within the scatter of the next).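

With a ring nitrogen on the triple-bonded carbon, the maximal response stays within the scatter of all three carbon-only rings: in this assay the steps are a number 6.6 percentage points higher from compound 2 to compound 4 (within the scatter) and a number 5.4 percentage points higher from compound 3 to compound 4 (within the scatter) and a number 5.7 percentage points higher from compound 1 to compound 4 (within the scatter) here. This position therefore takes pyridin-4-yl, with its hydrogen-bond acceptor, as well as phenyl and its fluorinated forms, with no change that stands clear of the scatter. Nothing measured here offers an explanation for this result. Going by these compounds, whether pyridin-3-yl, pyridin-2-yl or pyrimidin-5-yl would behave the same way remains open, and so does the effect of a fluoro group on the pyridine ring itself.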